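This account rests on a few compounds, and the source may have more. Where it says the series, first, only, none or still open, it means among the compounds named here.

Three compounds sharing one core have been examined in a physicochemical assay for acid dissociation. Compound 1 `CN(C)c1cccc(Oc2ccc3c(NCCCNCc4ccco4)ccnc3c2)c1` gives 9.28, compound 2 `COc1ccc(F)cc1CNCCCNc1ccnc2cc(Oc3cccc(N(C)C)c3)ccc12` gives 9.28, and compound 3 `COc1cccc(CNCCCNc2ccnc3cc(Oc4cccc(N(C)C)c4)ccc23)c1O` gives 9.28. Compound 2 thus stands level with compounds 1 and 3 at the digits shown. The three measured steps, no change at the digits printed from compound 1 to compound 2 (within the scatter), no change at the digits printed from compound 1 to compound 3 (within the scatter) and no change at the digits printed from compound 2 to compound 3 (within the scatter), all alter the aryl group on a saturated chain carbon bound to an amine nitrogen, and none of them shifts the reading beyond the scatter.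

Compound 4 `COc1ccc(F)cc1CNCCCNc1ccnc2cc(-c3ccc(C(C)(C)C)cc3)ccc12` differs from compound 2 elsewhere: 4-(tert-butyl)phenyl in place of 3-(dimethylamino)phenoxy on an aromatic carbon. Among the measured compounds shown here, no measured step touches that aromatic carbon, so the expectation rests only on the steadiness seen so far. The step from compound 2 to compound 4 is therefore expected to be small, about a number 0.08 log units lower from compound 2 to compound 4 (within the scatter). Compound 4 is expected to give 9.2, between 8.8 and 9.6.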

Compound 4, acid dissociation constant: 9.47
Estimate against measurement, compound 4: 0.27 log units below, within the range that was stated.
By their numbers in this assay, from the lowest: compounds 1, 2, 3 and 4 (each within the scatter of the next).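

Among the compounds shown here, compound 4 brings the first change at this aromatic carbon, and in this assay putting 4-(tert-butyl)phenyl in place of 3-(dimethylamino)phenoxy gives a number 0.19 log units higher from compound 2 to compound 4 (within the scatter) in a pair that differs only there. The reading thus stays within the scatter even when a group of carbon alone replaces one that holds a nitrogen and an oxygen. Nothing available explains this steadiness. On these data alone, whether a carboxylic acid or a primary amine on this aromatic carbon would leave the reading equally steady remains open.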